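A few compounds are considered here, and "the series" means these few. Any claim that something is new, unique, unknown or untested is made for them only; others in the source may bear on it.

Measured so far in a physicochemical assay for solubility, read by HPLC, using the shake flask method, measured as kinetic solubility, with a stated time of 20 h, at pH 6.5, tested at 200 uM; a higher number here means a more soluble compound, a lower number a less soluble compound:
Compound 1 `NS(=O)(=O)c1cncc(-c2ccc3nccc(-c4cn[nH]c4)c3n2)c1`: < 5000 nM, a limit
Compound 2 `CN1CCN(c2ccnc3ccc(-c4cccc(S(N)(=O)=O)c4)nc23)CC1`: 200000 nM
Compound 3 `NS(=O)(=O)c1cccc(-c2ccc3nccc(N4CCN(Cc5ccccc5)CC4)c3n2)c1`: < 5000 nM, a limit

Going by the values given here, compound 2 holds the only actual number here, 200000 nM. The other two compounds rest at the limit of < 5000 nM in this assay, at which 2 of the 3 values shown sit.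

Compound 4 `NS(=O)(=O)c1cccc(-c2ccc3nccc(-c4ccncc4F)c3n2)c1` is still unmeasured. It carries 3-fluoropyridin-4-yl in place of 4-methylpiperazin-1-yl on an aromatic carbon.

One measured step changes that same 4-methylpiperazin-1-yl group of compound 2. It is an at least 40-fold lower number from compound 2 to compound 3 (1.60 log units; beyond the scatter), with phenyl in place of hydrogen on a saturated chain carbon bound to an amine nitrogen in a ring. Going by that large step to compound 3, a large fall in this assay is expected here too, an estimated 50-fold lower number from compound 2 to compound 4 (1.70 log units; beyond the scatter). For compound 4 the estimated value is 4000 nM, with an expected range from 1000 nM to 15000 nM.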

Compound 4, solubility: < 5000 nM
Compound 4 was reported as a limit; the forecaster's own chance of this, stated with the estimate: 65%; the middle value does not contradict the limit.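

In this assay, the earlier step altered only the far end of the 4-methylpiperazin-1-yl group, whereas replacing the whole group with 3-fluoropyridin-4-yl on the same aromatic carbon also gives an at least 40-fold lower number from compound 2 to compound 4 (1.60 log units; beyond the scatter). For compound 4, < 5000 nM is a limit and not a number. Compound 2 thus remains the only compound with an actual number: the limit of < 5000 nM in this assay, at which 3 of the 4 values shown sit.

Going by these compounds, compound 3 and compound 4 cannot be ordered, and the full size of either step stays unknown. On these data alone, whether a morpholine or a dimethylamino group on this carbon would hold the value of compound 2 remains open.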